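Inverting one stereocentre from compound 2 to compound 3

The source may report more compounds than this note shows. Statements on the series, on what has been measured and on what is new or still open speak of the compounds shown alone.

In a functional assay on CCRF-CEM cells (Homo sapiens) for cytotoxicity (a lower number here means a stronger inhibitor, a higher number a weaker inhibitor), compound 1 (`Nc1ccn([C@H]2C=C(F)[C@H](CO)O2)c(=O)n1`) gives > 100000 nM, which is a limit and not a number. In this assay, compound 2 (`Nc1nc(=O)n([C@@H]2C=C(F)[C@H](CO)O2)cc1F`) gives > 100000 nM, which is also a limit. Among the measured compounds shown here, compound 2 therefore has no numerical value, and no measured step is available to size a change.

Compound 3 (`Nc1nc(=O)n([C@H]2C=C(F)[C@H](CO)O2)cc1F`) differs from compound 2 only in configuration as drawn: the two compounds have the same atoms and bonds and differ only in configuration as drawn: 1 of 2 stereo elements differ; a stereocentre at a saturated ring carbon is drawn S in compound 2 and R in compound 3. A stereocentre at a saturated ring carbon is drawn S in compound 2 and R in compound 3.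

The expectation rests mainly on compound 2 at > 100000 nM. The estimated step of an at least 1.2-fold lower number from compound 2 to compound 3 (0.09 log units; that floor lies within the scatter) is expected to stay within the scatter, with any larger move expected towards stronger inhibition. For compound 3, the expected value is 80000 nM, with an estimated range of 15000 nM to 100000 nM.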

Compound 3, half-maximal inhibitory concentration: > 100000 nM
Compound 3 was reported as a limit (the forecaster's own chance of this, stated with the estimate: 70%); middle value at least 1.2-fold (0.09 log units) from the limit.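

In this assay compound 3 gives > 100000 nM, a limit and not a number, so the steps to it from compound 1 and compound 2 cannot be read. As far as these compounds go, whether the changed stereocentre or fluoro in place of hydrogen alters cytotoxicity at all stays open.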